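From 4-nitrophenyl to 2-nitrophenyl in the series

A few compounds are considered here, and "the series" means these few. Any claim that something is new, unique, unknown or untested is made for them only; others in the source may bear on it.

Measured so far in a functional assay on HCT-116 cells (Homo sapiens) for antiproliferative activity, read by MTT assay, with a stated time of 72 h (a lower number here means a stronger inhibitor, a higher number a weaker inhibitor), on two compounds
- compound 1 `Cc1ccccc1N1CCN(C(=S)SCc2ccc3nc(N)nc(N)c3c2)CC1` gives 11800 nM
- compound 2 `Nc1nc(N)c2cc(CSC(=S)N3CCN(c4ccc([N+](=O)[O-])cc4)CC3)ccc2n1` gives 4680 nM

Compound 2 at 4680 nM holds the lower of the two numbers, and compound 1 is its nearest neighbour. Still unmeasured is compound 3 `Nc1nc(N)c2cc(CSC(=S)N3CCN(c4ccccc4[N+](=O)[O-])CC3)ccc2n1` which carries 2-nitrophenyl in place of 4-nitrophenyl on an amine nitrogen in a ring and is otherwise the same as compound 2.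

For the measured compounds named here, only one measured step bears on this change, namely a 2.5-fold lower number from compound 1 to compound 2 (0.40 log units; beyond the scatter) for 4-nitrophenyl in place of 2-methylphenyl on that nitrogen, and it is modest. Going by the values given here, no measured pair compares 2-nitrophenyl with 4-nitrophenyl directly. Compound 3 keeps the nitrophenyl of compound 2 but shares the 2-substituted naming of the 2-methylphenyl in compound 1 (11800 nM), so a small move toward a higher number is expected in this assay rather than a large one. The expected change is an estimated 1.4-fold higher number from compound 2 to compound 3 (0.14 log units; within the scatter) and should stay smaller than the measured step. Within this assay the estimate for compound 3 is 6500 nM with an expected range from 2800 nM to 15000 nM at this stage.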

Compound 3, half-maximal inhibitory concentration: 5520 nM
Compound 3: middle estimate off by 1.2-fold (0.07 log units), on the high side; the measured number falls inside the stated range.
By their numbers in this assay, from the lowest: compounds 2 and 3 (each within the scatter of the next); then compound 1.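

In this assay, moving the nitro group from 4-nitrophenyl to 2-nitrophenyl on the amine nitrogen in the ring gives a 1.2-fold higher number from compound 2 to compound 3 (0.07 log units; within the scatter), so the two nitrophenyl isomers cannot be told apart in this assay, and at these two places on the phenyl ring the place of the nitro group makes no readable difference. Compound 3 also supplies the cleaner comparison with compound 1, since the substituent changes while its place on the phenyl ring stays fixed: nitro in place of methyl gives a 2.1-fold lower number from compound 1 to compound 3 (0.33 log units; beyond the scatter), a modest step beyond the scatter, whereas the earlier step between compound 1 and compound 2 changed the group and its place together. Nothing shown gives a measured reason for either step.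
On these data alone, whether the modest gain belongs to nitro specifically remains open, as a nitrile, a methoxy group or a carboxylic acid on the same phenyl ring, or an unsubstituted phenyl, would be needed to test it. Also open, as far as these compounds go, is whether methyl responds to its place on the ring as nitro does here, which 4-methylphenyl would show, and whether 3-nitrophenyl matches the two nitrophenyl compounds at hand.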